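Phenyl replaces heptyl on the bromo-alkene core

This account rests on a few compounds, and the source may have more. Where it says the series, first, only, none or still open, it means among the compounds named here.

Compound 3 `CCCCCCCC1C=C(Br)CCN1S(=O)(=O)c1ccc(C)cc1` sits at the limit of a functional assay on A2780 cells (Homo sapiens) for antiproliferative activity, read by sulforhodamine B assay, with a stated time of 48 h (a higher number here means a weaker inhibitor of growth, a lower number a stronger inhibitor of growth), reported as > 100000 nM, which is a limit and not a number. Compound 2 `Cc1ccc(S(=O)(=O)N2CC=C(Br)CC2)cc1` is likewise reported only as the limit > 100000 nM. The step that the two limits leave unreadable from compound 2 to compound 3 therefore shows nothing about direction or size, since both ends are limits (the limit of > 100000 nM in this assay, at which 2 of the 3 values shown sit). Compound 1 `Cc1ccc(S(=O)(=O)N2CCC(Cl)=CC2c2ccccc2)cc1` carries a phenyl group and a chloro group where compound 4 carries phenyl and bromo; in this assay compound 1 gives 17000 nM. Going by the values given here, no step between compound 1 and compound 4 is computed here, so the value of compound 1 is taken only as a neighbouring point.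

Compound 4 `Cc1ccc(S(=O)(=O)N2CCC(Br)=CC2c2ccccc2)cc1` differs from compound 3 by phenyl in place of heptyl on a saturated ring carbon. Among the compounds with values here, the only measured step that bears on this position is unreadable, so the expectation rests on what compound 1 shows. The expected step of an at least 5.0-fold lower number from compound 3 to compound 4 (0.69 log units; beyond the scatter) is toward stronger inhibition, out of the limit region. Compound 4 is estimated at 20000 nM, with a range from 6000 nM to 70000 nM.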

Compound 4, concentration for 50% growth inhibition: 49000 nM
Compound 4: the middle estimate sits 2.5-fold (0.39 log units) below what was measured, within the range that was stated.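

In this assay, compound 4 is the first bromo compound in the series to give a number rather than a limit, so phenyl on this saturated ring carbon is the one change shown that brings the bromo-alkene core into a measurable range. Phenyl in place of heptyl gives an at least 2.0-fold lower number from compound 3 to compound 4 (0.30 log units; that floor lies within the scatter), and phenyl in place of hydrogen gives an at least 2.0-fold lower number from compound 2 to compound 4 (0.30 log units; that floor lies within the scatter); both are only floors, and each floor lies within the scatter. With phenyl held constant, bromo in place of chloro on the double-bonded ring carbon gives a 2.9-fold higher number from compound 1 to compound 4 (0.46 log units; beyond the scatter), a modest step toward weaker inhibition.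

As far as these compounds go, the true size of the phenyl gain stays open because compound 2 and compound 3 are limits: the limit of > 100000 nM in this assay, at which 2 of the 4 values shown sit. Also open is how an amine or a carboxylic acid at this position would compare with phenyl.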